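The compounds below may be only part of what the source reports. "The series", "measured", "known", "first", "only" and "open" are said of these compounds alone.

Compound 1 `COc1ccccc1Nc1nc(-c2cccc(F)c2)nc2ccc(F)cc12` is the starting point of this comparison. In a functional assay on U-937 cells (Homo sapiens) for cytotoxicity, read by MTT assay, with a stated time of 48 h (on this read-out higher numbers stand for weaker inhibition and lower numbers for stronger inhibition), compound 1 gives > 50000 nM, which is a limit of the assay and not a number. Compound 3 `Fc1cccc(-c2nc(Nc3ccccc3F)c3cc(F)ccc3n2)c1` also sits at a limit, giving > 50000 nM in this assay. Compound 2 `Fc1cccc(Nc2nc(-c3cccc(F)c3)nc3ccc(F)cc23)c1` gives 42300 nM in this assay. The whole set is shaped by the limit of > 50000 nM in this assay, at which 2 of the 3 values shown sit. The step of an at least 1.1-fold lower number from compound 1 to compound 2 (0.07 log units; that floor lies within the scatter) swaps the group on the same nitrogen that changes here, and an at least 1.1-fold higher number from compound 2 to compound 3 (0.07 log units; that floor lies within the scatter) stays equally small; a step that the two limits leave unreadable from compound 1 to compound 3. Compound 4 `Nc1cccc(Nc2nc(-c3cccc(F)c3)nc3ccc(F)cc23)c1` differs from compound 1 by 3-aminophenyl in place of 2-methoxyphenyl on a nitrogen on an aromatic ring. For the measured compounds named here, no measured step moved beyond the scatter, so no real shift in this assay is expected. Compound 4 is therefore estimated at 50000 nM, within 20000 nM to 150000 nM. That expectation corresponds to a number no higher from compound 1 to compound 4 (the limit leaves the size open).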

Compound 4, half-maximal inhibitory concentration: > 50000 nM
Compound 4 ended at the assay's limit (the forecaster's own chance of this, stated with the estimate: 65%); the middle value sits exactly at the limit.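

Amino in place of fluoro on an aromatic carbon gives an at least 1.1-fold higher number from compound 2 to compound 4 (0.07 log units; that floor lies within the scatter) in this assay. The steps to compound 4 from compound 1 and from compound 3 join two limits and cannot be read. Compared with 2-methoxyphenyl, 3-aminophenyl brings a hydrogen-bond donor, yet no stronger read-out appears at this nitrogen, and the set stays bounded by its limit: the limit of > 50000 nM in this assay, at which 3 of the 4 values shown sit.

As far as these compounds go, whether a hydroxyl or a carboxylic acid on this phenyl ring would give a value clearly under that limit remains open. So does how far the compounds at the limit differ from one another.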